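The source may hold more compounds than are shown below. What is called first, only, known or untested is meant among the compounds shown, and "the series" means these compounds.

Measured in a functional assay on PC-9 cells (Homo sapiens) for inhibition, read by MTT assay, with a stated time of 48 h, tested at 10 uM; a lower number here means less inhibition, a higher number more inhibition at the concentration tested (going by the name of the read-out):
compound 1, `COc1cc(NC(=O)Nc2cc(Nc3ccc(C(C)(C)C)cc3)ncn2)cc(OC)c1`, gives 74.1%
compound 2, `COc1cc(NC(=O)Nc2cc(Nc3ccc(C)c(C)c3)ncn2)cc(OC)c1`, gives 66%
compound 3, `COc1cc(NC(=O)Nc2cc(Nc3ccc(F)c(Cl)c3)ncn2)cc(OC)c1`, gives 77.5%

Compound 3 has the highest of the three numbers. Its nearest neighbour is compound 1, and the step of a number 3.4 percentage points higher from compound 1 to compound 3 (within the scatter) lies within the scatter, so no order between these two can be read. The furthest is compound 2: the step of a number 11.5 percentage points higher from compound 2 to compound 3 (beyond the scatter) lies beyond the scatter and is modest in size. The step of a number 8.1 percentage points lower from compound 1 to compound 2 (within the scatter) is again within the scatter.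

Compound 4, `COc1cc(NC(=O)Nc2cc(Nc3ccc(C)c(F)c3)ncn2)cc(OC)c1`, differs from compound 3 in one place: 3-fluoro-4-methylphenyl in place of 3-chloro-4-fluorophenyl on a nitrogen on an aromatic ring. Going by the values given here, the steps that bear on this change are the two that alter the same aryl group on the nitrogen. Replacing the 3,4-dimethylphenyl group by the 3-chloro-4-fluorophenyl group gave a number 11.5 percentage points higher from compound 2 to compound 3 (beyond the scatter); replacing the 4-(tert-butyl)phenyl group by the same 3-chloro-4-fluorophenyl group gave only a number 3.4 percentage points higher from compound 1 to compound 3 (within the scatter). Compound 4 keeps one fluorine and carries one methyl, so in composition it is intermediate between compound 2 and compound 3. A small decrease from compound 3 is therefore expected, probably within the scatter, as a number 6.5 percentage points lower from compound 3 to compound 4 (within the scatter). Compound 4 is estimated at 71% in this assay, with a range from 60% to 82%.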

Compound 4, a percentage reported as inhibition, at one concentration (the size of the read-out at that concentration, not a potency): 77.5%
Compound 4: middle estimate off by 6.5 percentage points, on the low side; measured number inside the range.
By their numbers in this assay, from the lowest: compounds 2, 1, 3 and 4 (each within the scatter of the next, the first and the last beyond it).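

In this assay, the exchange of 3-chloro-4-fluorophenyl for 3-fluoro-4-methylphenyl on the nitrogen gives no change at the digits printed from compound 3 to compound 4 (within the scatter), so the number stays level at this position with the loss of chlorine and the arrival of a methyl, without any readable shift, and the 3-chloro-4-fluorophenyl group is not needed to reach this level. The change of a single group, fluoro in place of methyl on an aromatic carbon, gives a number 11.5 percentage points higher from compound 2 to compound 4 (beyond the scatter), which shows that a methyl on this aryl group does not by itself go with the lower number, since compound 4 keeps one, while the step of a number 3.4 percentage points higher from compound 1 to compound 4 (within the scatter) allows no order against the 4-(tert-butyl)phenyl group. Nothing available explains why these aryl groups behave as they do.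

The compounds shown leave open how this position responds to an aryl group carrying an aminomethyl group or a carboxylic acid, as all four carry only halogens or alkyl groups there. They also leave open whether the shared level of inhibition at a single concentration conceals differences in potency.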